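Chloro for methylsulfanyl on the shared core

The source may hold more compounds than are shown below. What is called first, only, known or untested is meant among the compounds shown, and "the series" means these compounds.

Among the compounds with values here, the series so far holds two measured compounds. In a functional assay on HFF cells (Homo sapiens) for cytotoxicity (on this read-out lower numbers stand for stronger inhibition and higher numbers for weaker inhibition), compound 1 `CSc1nc(Cl)c2ccn(COCCOC(C)=O)c2n1` gives 100000 nM, the higher of the two numbers recorded. Within the data shown here, compound 2 `CSc1nc(Cl)c2ccn(COCCO)c2n1` gives 30000 nM in this assay, and the step of a 3.3-fold lower number from compound 1 to compound 2 (0.52 log units; beyond the scatter) is the only measured change on the core. Compound 3 `CC(=O)OCCOCn1ccc2c(Cl)nc(Cl)nc21` carries a different change: chloro in place of methylsulfanyl on an aromatic carbon. Among the measured compounds shown here, the one measured step concerns the acetyl on the side-chain oxygen, not the aromatic carbon where the methylsulfanyl sits, so no measured step bears on the move from compound 1 to compound 3, and the series gives no anchor for its direction. Within this gap the default expectation is a step that stays near the scatter, written as a 1.4-fold lower number from compound 1 to compound 3 (0.15 log units; within the scatter), which is an estimate and not a measurement. Compound 3 is therefore expected at about 70000 nM in this assay. The estimated range for compound 3 is expected to run from 20000 nM to 250000 nM, wide on both sides, with a fair chance that the assay reports only a limit for compound 3, as the number for compound 1 may already sit at the top of what it resolves.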

Compound 3, half-maximal inhibitory concentration: > 100000 nM
Compound 3: a limit, no number; the forecaster's own chance of this, stated with the estimate: 30%; at least 1.4-fold (0.15 log units) between middle value and limit.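

Chloro in place of methylsulfanyl, on the aromatic carbon between two ring nitrogen atoms, gives a number no lower from compound 1 to compound 3 (the limit leaves the size open), so this change on the shared core brings no lower number in this assay, unlike the side-chain step, a 3.3-fold lower number from compound 1 to compound 2 (0.52 log units; beyond the scatter). In this assay compound 3 gives > 100000 nM, which is a limit of the assay and not a number. The size of the step from the methylsulfanyl to the chloro compound cannot be read because the value sits at that limit: the limit of > 100000 nM in this assay, at which 1 of the 3 values shown sits.

Going by these compounds, whether an amine or a methoxy group on this aromatic carbon would give a number that can be read in this assay remains open. Also open, on these data alone, is whether hydrogen in place of acetyl on the side-chain oxygen would lower the number in the chloro series as it does in the methylsulfanyl series.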